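Working notes: from compound 2 to compound 3

This account rests on a few compounds, and the source may have more. Where it says the series, first, only, none or still open, it means among the compounds named here.

Measured in a functional assay on PC-3 cells (Homo sapiens) for inhibition, read by CellTiter-Glo, with a stated time of 72 h; a higher number here means that more compound is tolerated, a lower number that less compound is tolerated:
- compound 1 `CC1=C(CC(=O)N(C)CCN(C)S(C)(=O)=O)c2cc(F)ccc2/C1=C\c1ccc([S+](C)[O-])cc1`: 42600 nM
- compound 2 `CC1=C(CC(=O)N(C)CCN(C)S(=O)(=O)c2cccc3ccccc23)c2cc(F)ccc2/C1=C\c1ccc([S+](C)[O-])cc1`: 8960 nM

Compound 2 holds the lower of the two numbers in this assay. Among the compounds with values here, the only measured step is a 4.8-fold lower number from compound 1 to compound 2 (0.68 log units; beyond the scatter), with naphthalen-1-yl in place of methyl on a sulfonyl sulfur. Compound 3 `CC1=C(CC(=O)N(C)CCN(C)S(=O)(=O)c2cccc3c(N(C)C)cccc23)c2cc(F)ccc2/C1=C\c1ccc([S+](C)[O-])cc1` carries dimethylamino in place of hydrogen on an aromatic carbon. Within the data shown here, no measured step covers this change directly. Among the measured compounds shown here, the step of a 4.8-fold lower number from compound 1 to compound 2 (0.68 log units; beyond the scatter) shows only that a change in the sulfonyl substituent can move the number, and it says nothing about dimethylamino. A smaller move than that step is therefore expected. The expected step, toward a lower number and perhaps not beyond the scatter, is a 1.5-fold lower number from compound 2 to compound 3 (0.17 log units; within the scatter). For compound 3 the estimated value is 6000 nM, with an expected range of 2200 nM to 17000 nM.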

Compound 3, half-maximal cytotoxic concentration: 9200 nM
Estimate against measurement, compound 3: 1.5-fold (0.19 log units) below, within the range that was stated.
By their numbers in this assay, from the lowest: compounds 2 and 3 (each within the scatter of the next); then compound 1.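

In this assay, a 1.0-fold higher number from compound 2 to compound 3 (0.01 log units; within the scatter) stays within the scatter, so compound 2 and compound 3 cannot be told apart. The earlier step showed only that the substituent on the sulfonyl sulfur can move the number; this one shows that dimethylamino can stand in place of hydrogen on this aromatic carbon of the naphthalen-1-yl group without a readable difference in this read-out. No measurement at hand bears on why this change reads as it does.

Open, from the compounds shown here alone, is whether this carbon tolerates any substituent in this way, since a single group cannot show that; a carboxylic acid, a primary amine or a methoxy group there would test it. Also open, going by these compounds, is whether dimethylamino on another carbon of the fused system would give the same reading.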